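A few compounds are considered here, and "the series" means these few. Any claim that something is new, unique, unknown or untested is made for them only; others in the source may bear on it.

The compounds measured so far in an assay on HEK293 cells for displacement of a labelled ligand from Melanocortin receptor 4 (Homo sapiens); on this read-out lower numbers stand for stronger inhibition and higher numbers for weaker inhibition:

Compound 1, `CC(C)C[C@H](N)c1cc(C(F)(F)F)ccc1N1CCN(C(=O)C(C)Cc2ccc(Cl)cc2O)CC1`, gives 36 nM.
Compound 2, `CC(C)C[C@H](N)c1cc(C(F)(F)F)ccc1N1CCN(C(=O)COc2cccc3ccccc23)CC1`, gives 2600 nM.
Compound 3, `CC(C)C[C@H](N)c1ccccc1N1CCN(C(=O)[C@H](C)Cc2ccc(Cl)cc2F)CC1`, gives 67 nM.

Compound 1 has the lowest of the three numbers. Compound 3 lies closest to it, and the two values sit within the usual scatter of each other, so no order between them can be claimed. Compound 2 is furthest away, and that gap is the step of a 72-fold higher number from compound 1 to compound 2 (1.86 log units; beyond the scatter), well beyond the scatter.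

Compound 4, `CC(C)C[C@H](N)c1cc(C(F)(F)F)ccc1N1CCN(C(=O)CCC(=O)N(C)C)CC1`, has not yet been measured in this assay. It differs from compound 1 in one place: 2-(dimethylcarbamoyl)ethyl in place of 1-(4-chloro-2-hydroxybenzyl)ethyl on a carbonyl carbon. Within the data shown here, the one measured step that bears on this change is a 72-fold higher number from compound 1 to compound 2 (1.86 log units; beyond the scatter), in which the 1-(4-chloro-2-hydroxybenzyl)ethyl group also left the carbonyl carbon, there in favour of a group still carrying a ring. In compound 4 the group that enters has no ring at all, and nothing in the measured set shows a ringless chain at this position. A large step upward, comparable to or larger than that seen in the measured pair, is therefore expected. The expected step is an 83-fold higher number from compound 1 to compound 4 (1.92 log units; beyond the scatter). Compound 4 is estimated to give 3000 nM, with a range from 500 nM to 20000 nM.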

Compound 4, inhibition constant: > 10000 nM
Compound 4 gave a limit, no number; the forecaster's own chance of this, stated with the estimate: 20%; middle value at least 3.3-fold (0.52 log units) from the limit.
By their numbers in this assay, from the lowest: compounds 1 and 3 (each within the scatter of the next); then compound 2. At a limit, above all of these: compound 4.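

In this assay compound 4 gives a limit and not a number: the limit of > 10000 nM in this assay, at which 1 of the 4 values shown sits. Putting 2-(dimethylcarbamoyl)ethyl on the carbonyl carbon in place of 1-(4-chloro-2-hydroxybenzyl)ethyl gives an at least 270-fold higher number from compound 1 to compound 4 (2.44 log units; beyond the scatter), so a chain with no ring at this position is far from matching the group it replaces. The earlier compounds shown here showed only that a replacement still carrying a ring could give a much higher number, and the ringless chain goes further, with an at least 3.8-fold higher number from compound 2 to compound 4 (0.58 log units; beyond the scatter), although a ring alone does not secure a low number, as the earlier step already showed.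

The compounds shown cannot separate the loss of the ring from the entry of the dimethylcarbamoyl group, and the limit leaves the full size of both new steps unknown. Going by these compounds, how a plain butyl chain, or a chain ending in a carboxylic acid or an amine, would read in this assay stays open.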